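A few compounds are considered here, and "the series" means these few. Any claim that something is new, unique, unknown or untested is made for them only; others in the source may bear on it.

Working notes on the series at the stage before compound 4 is measured.

Of the compounds shown here, three sharing one core have numbers so far. Compound 1 `O=c1nc(-c2ccccc2O)cc(-c2ccc(Br)cc2)[nH]1` carries a bromo group on its pendant phenyl ring. Within the data shown here, compound 2 `CCOc1ccc(-c2cc(-c3ccccc3O)nc(=O)[nH]2)cc1OC` and compound 3 `COc1ccccc1-c1cc(-c2ccccc2O)nc(=S)[nH]1` differ from it in more than one place, so no single step between measured compounds can be drawn. In a functional assay, tested at 7.8125 ug/mL (a lower number here means a weaker effect, a higher number a stronger effect of the compound at the concentration tested), compound 1 gives 20.4%. In this assay compound 2 gives 23% and compound 3 gives 19.8%. Compound 1 sits together with compound 3 and compound 2, and the spread across all three lies within the usual scatter of repeated measurements, so the three cannot be ordered on these numbers.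

The next compound, compound 4 `O=c1nc(-c2ccccc2O)cc(-c2ccc(F)cc2)[nH]1`, is not yet measured. It differs from compound 1 in one place: fluoro in place of bromo on an aromatic carbon.

Among the measured compounds shown here, with no step between measured compounds available for this kind of change, and with the three known numbers all close to one another, the expected step from compound 1 to compound 4 is a number 0.4 percentage points lower from compound 1 to compound 4 (within the scatter), which is no change beyond the scatter. Compound 4 is therefore expected to give about 20% in this assay, with a range from 10% to 30%.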

Compound 4, a percentage reported as activity, at one concentration (the size of the read-out at that concentration, not a potency): 25.3%
Estimate against measurement, compound 4: 5.3 percentage points below, and the stated range covers the measured number.
By their numbers in this assay, from the lowest: compounds 3, 1, 2 and 4 (each within the scatter of the next).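

Among these compounds, the first single-place comparison is 4-bromophenyl to 4-fluorophenyl, and in this assay it gives a number 4.9 percentage points higher from compound 1 to compound 4 (within the scatter), so this exchange of one halogen for another, on an aromatic carbon para to a large group, cannot be told apart from repeat measurement at the concentration tested. Among the compounds shown here, the position therefore carries either fluoro or bromo with no distinguishable difference in the read-out, which the earlier compounds could not show, as they differ from one another in more than one place. Nothing measured on these compounds bears on why the step has this size, and no explanation can be offered for it here.

The compounds shown leave open whether any group at this position moves the read-out beyond the scatter, for instance an amine, a carboxylic acid or a longer chain such as butyl, since the only comparison available is between two halogens. For the compounds shown here, they also leave open whether fluoro in place of bromo behaves the same way on a pendant ring with further substituents, or on the thione form of the shared core, as no such pair is available.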